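Swapping a chlorophenyl for pyridinyl on the pyrrole nitrogen

A few compounds are considered here, and "the series" means these few. Any claim that something is new, unique, unknown or untested is made for them only; others in the source may bear on it.

Compound 1 `CCOC(=O)C1=C(C)N/C(=C/c2cc(C)n(-c3ccc(Cl)cc3)c2C)C1=O`: 1.6 ug/mL
Compound 2 `CCOC(=O)C1=C(C)N/C(=C/c2cc(C)n(-c3cc(OC)c(OC)c(OO)c3)c2C)C1=O`: 6.3 ug/mL

In a physicochemical assay for solubility, read by nephelometry, measured as kinetic solubility, at pH 2.0 (on this read-out lower numbers stand for lower solubility and higher numbers for higher solubility), compound 1 gives the lower of the two numbers shown, and compound 2 gives the higher one, a gap that lies beyond the scatter. Compound 3 `CCOC(=O)C1=C(C)N/C(=C/c2cc(C)n(-c3ccncc3)c2C)C1=O` has not been measured. It differs from compound 1 in one place: pyridin-4-yl in place of 4-chlorophenyl on an aromatic nitrogen. Among the measured compounds shown here, no step between measured compounds shows the effect of this exchange, so the expectation rests on the two values alone. Compound 3 is expected to give a higher number, with the step of a 25-fold higher number from compound 1 to compound 3 (1.40 log units; beyond the scatter) estimated as sizeable and the estimate for compound 3 set at 40 ug/mL, within the range 6 ug/mL to 200 ug/mL.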

Compound 3, solubility: 100 ug/mL
Beside the measured number, compound 3's estimate is 2.5-fold (0.40 log units) below it; measured number inside the range.
By their numbers in this assay, from the lowest: compound 1; then compound 2; then compound 3.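

In this assay, the exchange of 4-chlorophenyl for pyridin-4-yl on the aromatic nitrogen gives a 63-fold higher number from compound 1 to compound 3 (1.80 log units; beyond the scatter), the first single-place step read at this position. It shows that the number moves far beyond the scatter with this one exchange, even though a six-membered aromatic ring stays in place, next to two ring atoms that each bear a methyl group. No measurement given here accounts for the size of this step. The compounds shown leave open whether pyridin-3-yl would give a step of similar size. They also leave open how a phenyl ring carrying a carboxylic acid or a dimethylamino group would compare.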